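Shifting a Fluorine on a Fluorophenyl Group

The source may hold more compounds than are shown below. What is called first, only, known or untested is meant among the compounds shown, and "the series" means these compounds.

Compound 1 `CC(O)(C(=O)Nc1ccc(S(=O)(=O)c2ccccc2)c(F)c1)C(F)(F)F`: 1800 nM
Compound 2 `CC(O)(C(=O)Nc1ccc(S(=O)(=O)c2ccccc2O)cc1)C(F)(F)F`: 3090 nM
Compound 3 `CC(O)(C(=O)Nc1ccc(C(=O)c2ccccc2F)cc1)C(F)(F)F`: 2300 nM

Of the compounds shown here, three share a core and have been tested in a functional assay (Cavia porcellus) with sulfonylurea receptors; K-ATP channels (Homo sapiens) as the target; on this read-out lower numbers stand for stronger inhibition and higher numbers for weaker inhibition. Compound 1 gives 1800 nM, compound 2 gives 3090 nM and compound 3 gives 2300 nM. Compound 3 holds the second highest of the three numbers, yet its gaps to compound 1 and to compound 2 both lie within the usual scatter, so none of the three can be called stronger or weaker than another. Compound 4 `CC(O)(C(=O)Nc1ccc(C(=O)c2ccc(F)cc2)cc1)C(F)(F)F` differs from compound 3 in one place: 4-fluorophenyl in place of 2-fluorophenyl on a carbonyl carbon. For the measured compounds named here, no measured pair shows this change, so the expectation rests only on how close the three numbers so far sit. Compound 4 is expected to give about 2500 nM, with a range from 1000 nM to 6000 nM. The step of a 1.1-fold higher number from compound 3 to compound 4 (0.04 log units; within the scatter) is expected to stay within the scatter.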

Compound 4, half-maximal inhibitory concentration: 14000 nM
Compound 4: middle estimate off by 5.6-fold (0.75 log units), on the low side; the measured number lies above the stated range.
By their numbers in this assay, from the lowest: compounds 1, 3 and 2 (each within the scatter of the next); then compound 4.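

In this assay the change to 4-fluorophenyl in place of 2-fluorophenyl on a carbonyl carbon gives a 6.1-fold higher number from compound 3 to compound 4 (0.78 log units; beyond the scatter), even though the leaving and entering groups hold the same atoms. For the compounds shown here, this position therefore tells apart two groups that differ only in how those atoms are joined, and the earlier compounds showed no such step. Nothing measured here explains the step. One pair leaves open whether 4-chlorophenyl or 4-methoxyphenyl on the same carbonyl carbon would give numbers like compound 3 or like compound 4.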